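Swapping a sulfonyl imidazole for a cyclopentyl amide

A few compounds are considered here, and "the series" means these few. Any claim that something is new, unique, unknown or untested is made for them only; others in the source may bear on it.

Compound 1 has the structure `Cn1cnc(S(=O)(=O)N2CCC(CN(C3Cc4cc(C#N)ccc4N(Cc4cncn4C)C3)S(=O)(=O)c3ccccn3)CC2)c1`. Its companion in this set is compound 2, `Cn1cnc(S(=O)(=O)N(Cc2cccc(-n3cccc3)c2)C2Cc3cc(C#N)ccc3N(Cc3cncn3C)C2)c1`, which shares the same core but carries different groups on the outer positions. Both were run in an ADME assay on Caco-2 cells (Homo sapiens) for permeability, in the apical to basolateral direction (a higher number here means that the compound crosses the layer faster, a lower number that the compound crosses the layer more slowly), a test of how quickly a compound passes through a layer of gut-like cells. Compound 1 gives 0.1 10^-6 cm/s, and compound 2 gives 0.2 10^-6 cm/s. Compound 1 has the lower of the two numbers, but the gap to compound 2 lies within the scatter of repeated measurements, so the two cannot be told apart.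

Compound 3, `Cn1cncc1CN1CC(N(CC2CCN(C(=O)C3CCCC3)CC2)S(=O)(=O)c2ccccn2)Cc2cc(C#N)ccc21`, has not yet been measured. It differs from compound 1 in one place: cyclopentylcarbonyl in place of (1-methyl-1H-imidazol-4-yl)sulfonyl on an amine nitrogen in a ring. Among the measured compounds shown here, no pair of measured compounds shows what such a swap does in this assay, so there is no measured step to lean on.

The change from compound 1 to compound 3 is expected to raise the number in this assay modestly, by a 4.0-fold higher number from compound 1 to compound 3 (0.60 log units; beyond the scatter). Compound 3 is estimated to give 0.4 10^-6 cm/s, with a likely range from 0.1 10^-6 cm/s to 1.5 10^-6 cm/s.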

Compound 3, apparent permeability: 0.5 10^-6 cm/s
For compound 3 the middle estimate is 1.3-fold (0.10 log units) below the measured one; the measured number falls inside the stated range.
By their numbers in this assay, from the lowest: compounds 1 and 2 (each within the scatter of the next); then compound 3.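

Among the compounds shown here, at an amine nitrogen in a ring, cyclopentylcarbonyl in place of (1-methyl-1H-imidazol-4-yl)sulfonyl gives a 5.0-fold higher number from compound 1 to compound 3 (0.70 log units; beyond the scatter) in this assay, the first measured step at this position and one that lies beyond the scatter. The swap changes several things at once: a sulfonyl link becomes a carbonyl, a five-membered aromatic ring with 2 hetero atoms becomes a five-membered non-aromatic ring of carbon only, and 4 hydrogen-bond acceptors become 1 hydrogen-bond acceptor, so this single step cannot assign the rise to any one of these differences. Nothing measured here explains the rise.

Still open, going by these compounds, is whether the link or the ring accounts for the step, a question that cyclopentylsulfonyl or (1-methyl-1H-imidazol-4-yl)carbonyl at the same nitrogen could help to settle. Also open, on these data alone, is how an acetyl group, an open-chain pivaloyl group or a benzoyl group at this position would compare with cyclopentylcarbonyl, and so whether the size or the type of the acyl group has any bearing on the number.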